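From Hexyl to Isopropyl on a Carbonyl Carbon

The source may report more compounds than this note shows. Statements on the series, on what has been measured and on what is new or still open speak of the compounds shown alone.

Measured so far in a functional assay on the whole organism for antagonist activity, with Mus musculus as the target; on this read-out higher numbers stand for an effect only at larger amounts of compound and lower numbers for an effect already at smaller amounts:
- Compound 1 `CC(=O)NCC(=O)N(C)c1ccc(Cl)cc1C(=O)c1ccccc1Cl`: 2.3 mg/kg
- Compound 2 `CCCCCCC(=O)NCC(=O)N(C)c1ccc(Cl)cc1C(=O)c1ccccc1Cl`: 1.9 mg/kg

With only these two numbers available, compound 2 stands within the usual scatter of compound 1, so the pair cannot be ranked. Compound 3 `CC(C)C(=O)NCC(=O)N(C)c1ccc(Cl)cc1C(=O)c1ccccc1Cl` keeps the shared core and has isopropyl in place of hexyl on a carbonyl carbon.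

Within the data shown here, only one measured step bears on this change: a 1.2-fold lower number from compound 1 to compound 2 (0.08 log units; within the scatter). That step placed pentyl in place of hydrogen on a saturated chain carbon bound to a carbonyl carbon, so it altered the same chain. It stayed within the scatter, even though the chain changed substantially. Among the measured compounds shown here, no measured compound carries isopropyl, however, and a single step is thin evidence. The expected outcome in this assay is therefore no shift beyond the scatter in either direction, and the estimated 1.1-fold higher number from compound 2 to compound 3 (0.04 log units; within the scatter) reflects this. The estimated value for compound 3 is 2.1 mg/kg, with an expected range from 1 mg/kg to 4.5 mg/kg.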

Compound 3, dose for half-maximal effect: 6 mg/kg
Compound 3: middle estimate off by 2.9-fold (0.46 log units), on the low side; measured number above the stated range.
By their numbers in this assay, from the lowest: compounds 2 and 1 (each within the scatter of the next); then compound 3.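

In this assay, the group on this carbonyl carbon turns out to matter: a 3.2-fold higher number from compound 2 to compound 3 (0.50 log units; beyond the scatter), and a 2.6-fold higher number from compound 1 to compound 3 (0.42 log units; beyond the scatter), both modest but beyond the scatter. Methyl and hexyl had given numbers within the scatter of each other, which left open the possibility that this position tolerates almost any alkyl group, whereas isopropyl now shows that at least one such group requires a larger dose. The read-out also does not simply follow group size across these three compounds, since isopropyl is larger than methyl and smaller than hexyl yet gives the highest number of the three, and nothing available here explains this difference.

Going by these compounds, what remains open is whether the shift belongs to branching as such or to isopropyl alone, a question that straight-chain propyl, tert-butyl and cyclopropyl on the same carbonyl carbon would help to settle. With only three groups shown, it is also unknown how this position would respond to a chain ending in an amine or a carboxylic acid, or to a phenyl ring.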